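Trimethylsilyl to methoxyphenyl on the triazole of compound 3

The compounds below may be only part of what the source reports. "The series", "measured", "known", "first", "only" and "open" are said of these compounds alone.

Compound 3 `C[Si](C)(C)c1cn(C[C@H](O)[C@H]2OC(=O)C(OCc3ccccc3)=C2OCc2ccccc2)nn1` holds the lowest of the two numbers available in a functional assay on CFPAC-1 cells (Homo sapiens) for antiproliferative activity, read by MTT assay, with a stated time of 72 h (a higher number here means a weaker inhibitor, a lower number a stronger inhibitor), where compound 3 gives 52600 nM. Compound 2 `O=C1O[C@H]([C@@H](O)Cn2cc(-c3cc(F)cc(F)c3)nn2)C(OCc2ccccc2)=C1OCc1ccccc1` gives 62400 nM in this assay, a gap that sits within the scatter. Compound 1 `COc1ccccc1-c1cn(C[C@H](O)[C@H]2OC(=O)C(OCc3ccccc3)=C2OCc2ccccc2)nn1` reaches only the limit > 100000 nM in this assay. The change to compound 4 `COc1ccc(-c2cn(C[C@H](O)[C@H]3OC(=O)C(OCc4ccccc4)=C3OCc3ccccc3)nn2)cc1` is a group of 8 heavy atoms (7 carbon, 1 oxygen; one six-membered aromatic ring of carbon only) in place of a group of 4 heavy atoms (3 carbon, 1 silicon; no ring), on an aromatic carbon. Within the data shown here, two measured steps bear on it, each run in the opposite direction: an at least 1.9-fold lower number from compound 1 to compound 3 (0.27 log units; that floor lies within the scatter) and a 1.2-fold lower number from compound 2 to compound 3 (0.07 log units; within the scatter). Because an at least 1.9-fold lower number from compound 1 to compound 3 (0.27 log units; that floor lies within the scatter) and a 1.2-fold lower number from compound 2 to compound 3 (0.07 log units; within the scatter) both point the same way, compound 4 is expected to move back toward a higher number, by a modest amount. Compound 4 is therefore estimated at 85000 nM, range 40000 nM to 180000 nM, a step of a 1.6-fold higher number from compound 3 to compound 4 (0.21 log units; within the scatter).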

Compound 4, half-maximal inhibitory concentration: 26000 nM
Beside the measured number, compound 4's estimate is 3.3-fold (0.51 log units) above it; measured number outside the range, below it.
By their numbers in this assay, from the lowest: compound 4; then compounds 3 and 2 (each within the scatter of the next). At a limit, above all of these: compound 1.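

In this assay, an aryl group on this aromatic carbon now separates from trimethylsilyl, with a 2.0-fold lower number from compound 3 to compound 4 (0.31 log units; beyond the scatter) beyond the scatter. The aryl substitution also counts here, with a 2.4-fold lower number from compound 2 to compound 4 (0.38 log units; beyond the scatter) for 4-methoxyphenyl in place of 3,5-difluorophenyl and an at least 3.8-fold lower number from compound 1 to compound 4 (0.58 log units; beyond the scatter) for 4-methoxyphenyl in place of 2-methoxyphenyl. That last step is only a floor, set by a limit and not a number: the limit of > 100000 nM in this assay, at which 1 of the 4 values shown sits.

Open, from the compounds shown here alone, is whether an amine or a carboxylic acid in place of the methoxy of the 4-methoxyphenyl group would bring the number lower. Going by these compounds, a longer alkyl chain on this carbon also remains open.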